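Pyridinyl for Phenyl on a Second Core

The compounds below may be only part of what the source reports. "The series", "measured", "known", "first", "only" and "open" are said of these compounds alone.

Compound 1, `CCNC(=O)c1ccc(NC2CCCCC2)c(NCc2ccccc2)c1`: 21 nM
Compound 2, `CCNC(=O)c1ccc(NC2CCCCC2)c(NCc2ccncc2)c1`: 26 nM
Compound 3, `CCNS(=O)(=O)c1ccc(NC2CC3CCC2C3)c(NCc2ccccc2)c1`: 3 nM

Of the compounds shown here, three have been measured in a functional assay (IMR-32 cells, Homo sapiens) for inhibition, read by fluorescence, with stated times of 1 h and 13 h; on this read-out higher numbers stand for weaker inhibition and lower numbers for stronger inhibition. Compound 1 gives 21 nM. Compound 2, which carries pyridin-4-yl in place of phenyl on a saturated chain carbon bound to a nitrogen on an aromatic ring, gives 26 nM; the step of a 1.2-fold higher number from compound 1 to compound 2 (0.09 log units; within the scatter) shows that this change left the read-out essentially where it was. Compound 3 stands on a different core, and the difference between the two cores is not broken down here; in this assay compound 3 gives 3 nM, the lowest of the three numbers, beyond the scatter from both of the others.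

Compound 4, `CCNS(=O)(=O)c1ccc(NC2CC3CCC2C3)c(NCc2ccncc2)c1`, has not yet been measured. It differs from compound 3 by pyridin-4-yl in place of phenyl on a saturated chain carbon bound to a nitrogen on an aromatic ring, which is the same change, at the same place, as that from compound 1 to compound 2. On the one earlier occurrence of this change, the number hardly moved, and the expectation is therefore that compound 4 stays close to compound 3, with an expected step of a 1.2-fold higher number from compound 3 to compound 4 (0.08 log units; within the scatter). This rests on a single pair, so the spread is set generously. In this assay compound 4 is expected to give about 3.6 nM, most likely between 1.5 nM and 9 nM.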

Compound 4, half-maximal inhibitory concentration: 9.4 nM
The estimate for compound 4 lay 2.6-fold (0.42 log units) below the measured number; the whole stated range lies below it.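

In this assay, pyridin-4-yl in place of phenyl on a saturated chain carbon bound to a nitrogen on an aromatic ring gives a 3.1-fold higher number from compound 3 to compound 4 (0.50 log units; beyond the scatter), while the same change on the core of compound 1 gave a 1.2-fold higher number from compound 1 to compound 2 (0.09 log units; within the scatter). Among the compounds shown here, although only the step on the core of compound 3 lies beyond the scatter when read alone, the two steps cannot be told apart when set side by side: the same change on two cores in this assay, a 1.2-fold higher number (0.09 log units; within the scatter) from compound 1 to compound 2 and a 3.1-fold higher number (0.50 log units; beyond the scatter) from compound 3 to compound 4, 2.5-fold (0.40 log units) apart, within the scatter of two such steps. For the compounds shown here, this does not show that the change behaves differently on the two cores, and with only two pairs it does not establish that the change carries over reliably from one core to another either.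

The compounds shown leave open how other groups would fare at this place, such as pyridin-3-yl, pyridin-2-yl or a phenyl ring bearing a carboxylic acid. They also leave open whether a third core, for instance one bearing a primary amine, would give a step of similar size for the same change.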